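This account rests on a few compounds, and the source may have more. Where it says the series, first, only, none or still open, it means among the compounds named here.

Compound 1 `CCCC#Cc1cc([C@@H]2O[C@H](CO)[C@@H](O)[C@H]2O)n2ncnc(N)c12` gives 400 nM in a functional assay on NCI-H460 cells (Homo sapiens) for antiproliferative activity, with a stated time of 72 h; on this read-out lower numbers stand for stronger inhibition and higher numbers for weaker inhibition. Compound 2 `Nc1ncnn2c([C@@H]3O[C@H](CO)[C@@H](O)[C@H]3O)cc(C#CC3CC3)c12` gives 80 nM. Compound 3 `Nc1ncnn2c([C@@H]3O[C@H](CO)[C@@H](O)[C@H]3O)cc(C#Cc3ccc(F)cc3)c12` gives 79400 nM.

Among these three numbers compound 1 holds the second highest. Its nearest neighbour is compound 2, reached by a 5.0-fold lower number from compound 1 to compound 2 (0.70 log units; beyond the scatter); its furthest is compound 3, reached by a 200-fold higher number from compound 1 to compound 3 (2.30 log units; beyond the scatter). The pair of compounds 2 and 3 marks out the whole spread, a 990-fold higher number from compound 2 to compound 3 (3.00 log units; beyond the scatter).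

The unmeasured compound 4 `Nc1ncnn2c([C@@H]3O[C@H](CO)[C@@H](O)[C@H]3O)cc(-c3ccc(Cl)cc3)c12` differs from compound 1 in one place: 4-chlorophenyl in place of pent-1-yn-1-yl on an aromatic carbon. Among the measured compounds shown here, no measured step removes the triple bond from this position, so none matches the change exactly. The closest guide is the step to compound 3, where a six-membered aromatic ring with a halogen entered at the same place and the number rose sharply, a 200-fold higher number from compound 1 to compound 3 (2.30 log units; beyond the scatter). Compound 4 likewise carries a halogen-bearing aromatic ring here, though bonded directly to the core. A large rise in the number is therefore expected for compound 4, in the direction shown by compound 3, with wide uncertainty since the triple bond is gone.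

For compound 4 the expected result is 30000 nM, within a range of 2000 nM to 400000 nM, which means an estimated 75-fold higher number from compound 1 to compound 4 (1.88 log units; beyond the scatter).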

Compound 4, half-maximal inhibitory concentration: 45900 nM
Compound 4: the middle estimate sits 1.5-fold (0.18 log units) below what was measured; measured number inside the range.
By their numbers in this assay, from the lowest: compound 2; then compound 1; then compounds 4 and 3 (each within the scatter of the next).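

In this assay, the result shows that removing the triple bond does not bring the number down when an aromatic ring sits at this position: 4-chlorophenyl bonded directly to the aromatic carbon gives a 110-fold higher number from compound 1 to compound 4 (2.06 log units; beyond the scatter), and likewise a 570-fold higher number from compound 2 to compound 4 (2.76 log units; beyond the scatter). Compound 3 and compound 4 stand level, with a 1.7-fold lower number from compound 3 to compound 4 (0.24 log units; within the scatter), so a halogen-bearing phenyl ring is tied to a high number here whether it is joined through a triple bond or directly, and none of the four compounds goes against this. Nothing available here accounts for the gap between these two compounds and the two with small groups on the triple bond.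

The compounds shown leave open whether the triple bond or the group at its end sets the low numbers of compound 1 and compound 2, a question that a propyl or a cyclopropyl bonded directly to this aromatic carbon would address. Also open, from the compounds shown here alone, is how a phenyl without halogen, or a ring carrying an amine, would read at the same place.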